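The source may report more compounds than this note shows. Statements on the series, on what has been measured and on what is new or still open speak of the compounds shown alone.

Among the compounds with values here, compound 1 `Cc1nc(N)sc1CCCN/C(N)=N/C(=O)NCC(C)C1CCCCC1` gives 39.8 nM in an assay on membranes from Sf9 cells for displacement of a labelled ligand from histamine H2 receptor (Homo sapiens), read by scintillation counting, with a stated time of 60 min (on this read-out lower numbers stand for stronger inhibition and higher numbers for weaker inhibition), the lowest of the two numbers so far, and compound 2 `Cc1nc(N)sc1CCCN/C(N)=N/C(=O)NCC(C)CCCc1ccccc1` gives 60.3 nM. The step of a 1.5-fold higher number from compound 1 to compound 2 (0.18 log units; within the scatter) covers an exchange at a different position. Compound 3 `CCCCCNC(=O)/N=C(\N)NCCCc1sc(N)nc1C` differs from compound 1 by butyl in place of 1-cyclohexylethyl on a saturated chain carbon bound to an amide-type nitrogen. Within the data shown here, the only measured step, from compound 1 to compound 2, changed the group on the chain carbon beyond the one altered here, so it bears only loosely on this case. The expected step is a 2.5-fold higher number from compound 1 to compound 3 (0.40 log units; beyond the scatter), a modest weakening. The estimate for compound 3 is 100 nM, with a range from 40 nM to 300 nM.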

Compound 3, inhibition constant: 4.47 nM
Beside the measured number, compound 3's estimate is 22-fold (1.35 log units) above it; the whole stated range lies above it.
By their numbers in this assay, from the lowest: compound 3; then compounds 1 and 2 (each within the scatter of the next).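

Exchanging 1-cyclohexylethyl for butyl gives an 8.9-fold lower number from compound 1 to compound 3 (0.95 log units; beyond the scatter), so the group on this saturated chain carbon bound to an amide-type nitrogen clearly affects the result. The earlier step, a 1.5-fold higher number from compound 1 to compound 2 (0.18 log units; within the scatter), lay within the scatter and revealed no such sensitivity. Here, a ring in this group is not needed for strong inhibition, and the smaller butyl group does better. No available evidence explains this gain. Going by these compounds, it remains open whether losing the ring or shortening the group matters more; a straight octyl chain could help separate the two.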